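This account rests on a few compounds, and the source may have more. Where it says the series, first, only, none or still open, it means among the compounds named here.

Three compounds share one core and differ only in the group carried on a saturated chain carbon bound to an aromatic nitrogen. In a physicochemical assay for lipophilicity, at pH 7.4 (on this read-out higher numbers stand for higher lipophilicity and lower numbers for lower lipophilicity), compound 1 `CNC(=O)c1cc(C(=O)NC2CC2)cn(Cc2cccc3cc[nH]c23)c1=O` gives 3.7, compound 2 `CNC(=O)c1cc(C(=O)NC2CC2)cn(Cc2cccc3cn[nH]c23)c1=O` gives 2.2, and compound 3 `CNC(=O)c1cc(C(=O)NC2CC2)cn(Cc2cccc(C#N)c2)c1=O` gives 2.6, which is the second highest of the three, with a step of a number 0.40 log units higher from compound 2 to compound 3 (beyond the scatter) and a step of a number 1.10 log units lower from compound 1 to compound 3 (beyond the scatter). Compound 4 `CNC(=O)c1cc(C(=O)NC2CC2)cn(Cc2cccc(F)c2)c1=O` differs from compound 3 by fluoro in place of cyano on an aromatic carbon. Going by the values given here, none of the measured steps exchanges cyano for fluoro; each of them swaps the whole aromatic group, so they offer no direct guide to the size of this smaller change. Compound 4 is expected to give 3.1, with a range from 2.6 to 3.6, which would mean a number 0.50 log units higher from compound 3 to compound 4 (beyond the scatter).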

Compound 4, distribution coefficient: 3.2
Beside the measured number, compound 4's estimate is 0.10 log units below it, within the range that was stated.
By their numbers in this assay, from the lowest: compound 2; then compound 3; then compound 4; then compound 1.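

Exchanging only the substituent rather than the whole aromatic group gives a number 0.60 log units higher from compound 3 to compound 4 (beyond the scatter) in this assay, so a change of one small group on this aromatic carbon is enough to shift the number clearly. Set against the larger groups, 3-fluorophenyl gives a number 1.00 log units higher from compound 2 to compound 4 (beyond the scatter) and a number 0.50 log units lower from compound 1 to compound 4 (beyond the scatter), placing it inside the span of the 1H-indazol-7-yl and 1H-indol-7-yl compounds. Nothing available gives a cause for these shifts. Where an amine, a methoxy group or chloro on this aromatic carbon would fall remains open. So does whether fluoro in place of cyano gives a step of this size on another core.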